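The source may hold more compounds than are shown below. What is called first, only, known or untested is meant among the compounds shown, and "the series" means these compounds.

Four compounds share one core and differ only in two places: the length of the chain that ends in a dimethylamino group, and the ring attached to the core. Compound 1 `CN(C)CCCn1c(N)c(-c2nc3ccccc3o2)c2nc(C#N)c(C#N)nc21` was tested in a functional assay on HL60/MX2 cells (Homo sapiens) for antiproliferative activity, read by MTT assay, with a stated time of 48 h (a lower number here means a stronger inhibitor, a higher number a weaker inhibitor), and compound 1 gives 1310 nM there. Compound 2 `CN(C)CCCCn1c(N)c(-c2nc3ccccc3o2)c2nc(C#N)c(C#N)nc21` differs from compound 1 by (dimethylamino)methyl in place of dimethylamino on a saturated chain carbon, three bonds along the chain from an aromatic nitrogen, and in this assay compound 2 gives 960 nM; this lengthening of the chain made a 1.4-fold lower number from compound 1 to compound 2 (0.14 log units; within the scatter). Compound 3 `CN(C)CCCn1c(N)c(-c2nc3ccccc3s2)c2nc(C#N)c(C#N)nc21` keeps the shorter chain but carries a different ring, (1,3-benzothiazol-2-yl in place of 1,3-benzoxazol-2-yl on an aromatic carbon), and in this assay compound 3 gives 1310 nM, which is no change at the digits printed from compound 1 to compound 3 (within the scatter). The three numbers sit close together, so no one of them can be called stronger or weaker than the others.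

Compound 4 `CN(C)CCCCn1c(N)c(-c2nc3ccccc3s2)c2nc(C#N)c(C#N)nc21` has not yet been measured. It differs from compound 3 by (dimethylamino)methyl in place of dimethylamino on a saturated chain carbon, three bonds along the chain from an aromatic nitrogen, the same change that was made from compound 1 to compound 2, at the same place, now on the core of compound 3. The step from compound 3 to compound 4 in this assay is expected to be a 1.4-fold lower number from compound 3 to compound 4 (0.14 log units; within the scatter), matching the earlier one, because a 1.4-fold lower number from compound 1 to compound 2 (0.14 log units; within the scatter) was small and because no change at the digits printed from compound 1 to compound 3 (within the scatter) showed the two cores behaving alike. Compound 4 is therefore estimated to give about 950 nM, with a likely range from 500 nM to 1800 nM.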

Compound 4, half-maximal inhibitory concentration: 2140 nM
For compound 4 the middle estimate is 2.3-fold (0.35 log units) below the measured one; measured number outside the range, above it.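

The chain change from 3-(dimethylamino)propyl to 4-(dimethylamino)butyl gave a 1.6-fold higher number from compound 3 to compound 4 (0.21 log units; within the scatter) in this assay, and this step cannot be told apart from the same change made earlier on the benzoxazole-bearing compounds: the same change on two cores in this assay, a 1.4-fold lower number (0.14 log units; within the scatter) from compound 1 to compound 2 and a 1.6-fold higher number (0.21 log units; within the scatter) from compound 3 to compound 4, 2.2-fold (0.35 log units) apart, within the scatter of two such steps. Within the data shown here, the swap of 1,3-benzoxazol-2-yl for 1,3-benzothiazol-2-yl on the longer chain gave a 2.2-fold higher number from compound 2 to compound 4 (0.35 log units; beyond the scatter), the one new step beyond the scatter, yet it too cannot be separated from the same swap on the shorter chain: the same change on two cores in this assay, no change at the digits printed (within the scatter) from compound 1 to compound 3 and a 2.2-fold higher number (0.35 log units; beyond the scatter) from compound 2 to compound 4, 2.2-fold (0.35 log units) apart, within the scatter of two such steps. Neither change is therefore shown to behave differently from one partner to the other, but this does not prove that either carries over unchanged, since each comparison rests on a single pair of steps and steps this small could hide a real difference.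

The compounds shown leave open what a longer chain, such as 5-(dimethylamino)pentyl, would do on either ring. They also leave open whether a different amine at the chain end, such as a pyrrolidine or a morpholine, or a plain phenyl ring in place of the two fused rings, would give steps clearly larger than these.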